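The source may report more compounds than this note shows. Statements on the series, on what has been measured and on what is new or still open speak of the compounds shown alone.

Measured so far in an assay on CHO cells for displacement of a labelled ligand from Substance-P receptor (Homo sapiens); on this read-out lower numbers stand for stronger inhibition and higher numbers for weaker inhibition:
- compound 1 `COc1ccccc1N1CCN(C(=O)CCc2c(-c3ccc(Cl)cc3)[nH]c3ccc(C)cc23)CC1` gives 0.6 nM
- compound 2 `COc1ccccc1N1CCN(C(=O)CCc2c(-c3ccc(-c4ccccc4)cc3)[nH]c3ccc(C)cc23)CC1` gives 7.6 nM
- compound 3 `Cn1c(-c2cccnc2)c(CCC(=O)N2CCC(O)(Cc3ccccc3)CC2)c2cc(Cl)ccc21` gives 0.92 nM

On these three numbers compound 3 stands second highest. Its nearest neighbour is compound 1, and that gap lies within the usual scatter, so no order between compound 1 and compound 3 can be claimed. Compound 2 lies furthest from compound 3, and that gap is beyond the scatter.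

Compound 4 `Cn1c(-c2ccc(C(F)(F)F)cn2)c(CCC(=O)N2CCC(O)(Cc3ccccc3)CC2)c2cc(Cl)ccc21` differs from compound 3 in one place: 5-(trifluoromethyl)pyridin-2-yl in place of pyridin-3-yl on an aromatic carbon. Among the compounds with values here, no measured pair exchanges the pendant aryl itself, so no step speaks directly to this change. Within the data shown here, the only measured step, a 13-fold higher number from compound 1 to compound 2 (1.10 log units; beyond the scatter), concerns the group carried by the pendant aryl of the shared core, and it shows that enlarging that region produced a large move towards weaker inhibition. Compound 4 also enlarges the pendant aryl, by a trifluoromethyl, while the ring nitrogen is kept, so a step in the weaker direction is expected for compound 4, but a more modest one than that seen between compound 1 and compound 2.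

For compound 4 the expected number in this assay is 2.2 nM, with a range of 0.6 nM to 8 nM. The expected step is therefore a 2.4-fold higher number from compound 3 to compound 4 (0.38 log units; beyond the scatter).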

Compound 4, half-maximal inhibitory concentration: 0.12 nM
Compound 4: middle estimate off by 18-fold (1.26 log units), on the high side, outside the stated range (below it).
By their numbers in this assay, from the lowest: compound 4; then compounds 1 and 3 (each within the scatter of the next); then compound 2.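

At this aromatic carbon, next to the ring nitrogen, 5-(trifluoromethyl)pyridin-2-yl with 10 heavy atoms is accepted in place of pyridin-3-yl with 6 heavy atoms, and in this assay the change gives a 7.7-fold lower number from compound 3 to compound 4 (0.88 log units; beyond the scatter). Within the data shown here, this is the first measured exchange of the aryl group at this position, and the larger group goes with stronger inhibition, whereas the larger group in the only earlier step gave a 13-fold higher number from compound 1 to compound 2 (1.10 log units; beyond the scatter); the two pairs therefore show no single direction for enlargement, with compound 2 going against any reading that larger is better and compound 4 against any reading that larger is worse. Among these compounds, nothing measured so far gives a reason for the result of compound 4.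

The compounds shown leave open how much of the step belongs to the trifluoromethyl and how much to the change from pyridin-3-yl to pyridin-2-yl, since both change together in this one exchange. Also open, on these data alone, is whether an unsubstituted pyridin-2-yl, or a pyridin-2-yl carrying a nitrile or a methyl in place of the trifluoromethyl, would give a number close to that of compound 4 0.12 nM.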